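The source may hold more compounds than are shown below. What is called first, only, known or untested is meant among the compounds shown, and "the series" means these compounds.

Measured compounds:
Compound 1 `CCOC(=O)Oc1cc(-c2cncnc2-c2cc(OC)c(OC)c(OC)c2)ccc1OC`: 650 nM
Compound 2 `CCSc1ccc(-c2cncnc2-c2cc(OC)c(OC)c(OC)c2)cc1`: 370 nM
Compound 3 `CCOc1ccc(-c2cncnc2-c2cc(OC)c(OC)c(OC)c2)cc1F`: 470 nM

In a functional assay on HeLa cells (Homo sapiens) for antiproliferative activity, read by CCK-8 assay, with a stated time of 72 h (on this read-out higher numbers stand for weaker inhibition and lower numbers for stronger inhibition), compound 2 gives 370 nM and lies within the scatter of both compound 3 and compound 1, so it cannot be separated from either on these numbers.

Compound 4 `COc1cc(-c2ncncc2-c2ccc(Br)cc2)cc(OC)c1OC` has not yet been measured. It has bromo in place of ethylsulfanyl on an aromatic carbon, para to a large group (bromo in place of ethylsulfanyl on an aromatic carbon). The same difference can be read as 4-(ethylsulfanyl)phenyl to 4-bromophenyl.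

Among the measured compounds shown here, no two measured compounds differ in one place only, and none of them carries bromo, so the series offers no direct step to carry over. For the measured compounds named here, the only guide is the set of values in this assay, where compound 3 gives 470 nM and compound 1 gives 650 nM. Against that background, a large shift is not the default expectation, though the data cannot exclude one.

The expected change is a 1.9-fold higher number from compound 2 to compound 4 (0.28 log units; within the scatter), a modest one towards weaker inhibition that may not clear the scatter. For compound 4 the estimated value is 700 nM, with an expected range from 200 nM to 2500 nM.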

Compound 4, half-maximal inhibitory concentration: 500 nM
Compound 4: the middle estimate sits 1.4-fold (0.15 log units) above what was measured, within the range that was stated.
By their numbers in this assay, from the lowest: compounds 2, 3, 4 and 1 (each within the scatter of the next).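

In this assay, placing bromo instead of ethylsulfanyl on the aromatic carbon, para to a large group, gives a 1.4-fold higher number from compound 2 to compound 4 (0.13 log units; within the scatter). Among the compounds shown here, this is the first comparison that isolates one place, and it shows that the two groups cannot be told apart on this read-out, even though bromo has no sulfur, no carbon chain and no hydrogen-bond acceptor. On these two compounds, then, the ethylsulfanyl group is not required for activity in this range at this position, and no measured evidence bears on why the two groups read alike.

On these data alone, both groups compared here are small, uncharged and without a ring, so it remains open whether an amine, a carboxylic acid, a longer alkyl chain or a phenyl ring at this position would stay in the same range or move clearly beyond the scatter. For the compounds shown here, compound 1 and compound 3 differ from these two in more than one place, so no steps involving them can be read, and the separate contributions of the ethoxy, fluoro and ethyl carbonate groups stay unresolved.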